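The source may hold more compounds than are shown below. What is called first, only, known or untested is meant among the compounds shown, and "the series" means these compounds.

Compound 1 `COc1cccc(N2CCN(C(=O)C(C)N3C(=O)CCC3=O)CC2)c1` and compound 2 `CCC(C(=O)N1CCN(c2cccc(OC)c2)CC1)N1C(=O)CCC1=O` share one core, and compound 3 `CC(C(=O)N1CCN(c2ccccc2C(F)(F)F)CC1)N1C(=O)CCC1=O` and compound 4 `CCC(C(=O)N1CCN(c2ccccc2C(F)(F)F)CC1)N1C(=O)CCC1=O` share another; the difference between the two cores is not broken down here. In a functional assay on the whole organism (strain Swiss) with Mus musculus as the target, in the maximal electroshock model, with a stated time of 1 h, at a dose of 300 mg/kg by the intraperitoneal route (a lower number here means a weaker effect, a higher number a stronger effect of the compound at the dose given), compound 1 gives 0%, and compound 2 gives 0%. The change between them is methyl in place of hydrogen on a saturated chain carbon, two bonds along the chain from an amide-type nitrogen in a ring and a carbonyl carbon and it made no change at the digits printed from compound 1 to compound 2 (within the scatter). In this assay compound 3 gives 75%. Compound 4 carries the same change on the other core, (methyl in place of hydrogen on a saturated chain carbon, two bonds along the chain from an amide-type nitrogen in a ring and a carbonyl carbon). The earlier step rested on two values where no activity was found, so it says little about what the change does where activity is present. A step of a number 15 percentage points lower from compound 3 to compound 4 (beyond the scatter) is expected because compound 3 starts at 75%. For compound 4 a value of 60% is estimated, within the range 25% to 90%.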

Compound 4, a percentage reported as activity, at one dose (the size of the read-out at that dose, not a potency): 0%
Estimate against measurement, compound 4: 60 percentage points above; the whole stated range lies above it.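

In this assay, methyl in place of hydrogen on this chain carbon costs all of the activity seen, with a number 75 percentage points lower from compound 3 to compound 4 (beyond the scatter) on the core of compound 3, so on this evidence the change does not carry over from one core to the other with the same result: the same change on two cores in this assay, no change at the digits printed (within the scatter) from compound 1 to compound 2 and a number 75 percentage points lower (beyond the scatter) from compound 3 to compound 4, 75 percentage points apart, beyond the scatter of two such steps. The earlier pair offered little guide, since compound 1 gives 0% and compound 2 gives 0%, leaving no activity there to lose. Two pairs at one dose do not show why the cores part ways, nor how the change behaves on any further core.

The compounds shown leave open whether a longer chain such as propyl on this carbon gives the same result. They also leave open how a fluorine or a chlorine on the aromatic ring, in place of trifluoromethyl, would alter the effect of the change.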